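The source may hold more compounds than are shown below. What is called first, only, known or untested is meant among the compounds shown, and "the series" means these compounds.

Measured so far in a functional assay on KETR3 cells (Homo sapiens) for inhibition, read by MTT assay, with a stated time of 120 h; on this read-out lower numbers stand for stronger inhibition and higher numbers for weaker inhibition:
- Compound 1 `O=C(/C=C/c1ccc(NC(=O)Nc2ccc(Cl)c(C(F)(F)F)c2)cc1)NC1CCC1`: 17300 nM
- Compound 2 `CC(NC(=O)c1ccc(-c2ccc(NC(=O)Nc3cc(C(F)(F)F)ccc3Cl)cc2)cc1)c1ccccc1`: 16800 nM

Compound 1 stands level with compound 2: their two values lie within the usual scatter of each other, so neither can be called the stronger inhibitor.

The next compound to be tested is compound 3 `CNC(=O)/C=C(\C)c1ccc(NC(=O)Nc2ccc(Cl)c(C(F)(F)F)c2)cc1`. Going from compound 1 to compound 3, 1-methyl-2-(methylcarbamoyl)ethenyl takes the place of 2-(cyclobutylcarbamoyl)ethenyl on an aromatic carbon, para to a large group: 1-methyl-2-(methylcarbamoyl)ethenyl in place of 2-(cyclobutylcarbamoyl)ethenyl on an aromatic carbon.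

For the measured compounds named here, no measured pair shows a change of this kind, so the forecast rests on little. Compound 1 at 17300 nM and compound 2 at 16800 nM differ widely in structure, yet their values agree within the scatter. In this assay, no step beyond the scatter is therefore expected, and no direction is favoured. The expected step is a 1.0-fold higher number from compound 1 to compound 3 (0.02 log units; within the scatter). Compound 3 is estimated at 18000 nM, with an expected range from 6000 nM to 45000 nM.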

Compound 3, half-maximal inhibitory concentration: > 50000 nM
Compound 3: no number, only a limit (the forecaster's own chance of this, stated with the estimate: 15%); middle value at least 2.7-fold (0.44 log units) away from the limit.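

For the compounds shown here, until now no step between measured compounds could be read, and this one shows that the aromatic carbon para to a large group does not tolerate every side chain in this assay. Putting 1-methyl-2-(methylcarbamoyl)ethenyl in place of 2-(cyclobutylcarbamoyl)ethenyl gives an at least 2.8-fold higher number from compound 1 to compound 3 (0.46 log units; beyond the scatter) and so weaker inhibition, a change beyond the usual scatter. The full size of this step stays unknown because compound 3 gives only a limit of the assay and not a number: the limit of > 50000 nM in this assay, at which 1 of the 3 values shown sits.

This single change removes the cyclobutyl ring and adds a methyl on the ethenyl chain, and the compounds shown leave open which of the two matters. Also open, on these data alone, is how this assay would respond to an amine or a carboxylic acid at this position.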